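This account rests on a few compounds, and the source may have more. Where it says the series, first, only, none or still open, it means among the compounds named here.

Compound 2, `CCOC(=O)C1=C(Nc2ccc(Br)cc2)S/C(=C\c2ccc[nH]2)C1=O`, is tested in a functional assay on A549 cells (Homo sapiens) for inhibition, read by MTT assay, with a stated time of 72 h, tested at 10 uM (a higher number here means more inhibition at the concentration tested (going by the name of the read-out), a lower number less inhibition), where compound 2 gives only a limit, < 10%. That result sits at the lowest edge of what the read-out reports (the limit of < 10% in this assay, at which 1 of the 2 values shown sits). Within the data shown here, compound 1, `CCOC(=O)C1=C(Nc2ccccc2)S/C(=C\c2ccccc2)C1=O`, gives 29.6% in this assay; compound 1 and compound 2 differ in more than one place, so no single step between them is counted here. Compound 3, `CCOC(=O)C1=C(Nc2ccc(C)cc2)S/C(=C\c2ccc[nH]2)C1=O`, is not yet measured. Its change from compound 2 is methyl in place of bromo on an aromatic carbon. Among the measured compounds shown here, no measured pair shows a bromo-to-methyl swap, so the size of the step from compound 2 to compound 3 in this assay can only be guessed; a small step in either direction, probably not beyond the usual scatter, is expected. Compound 3 is therefore expected to give about 12%, within 3% to 28%. The step this expectation means is a number at least 2 percentage points higher from compound 2 to compound 3 (that floor lies within the scatter), an estimate rather than a measurement.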

Compound 3, a percentage reported as inhibition, at one concentration (the size of the read-out at that concentration, not a potency): 20.9%
The estimate for compound 3 lay 8.9 percentage points below the measured number; low and high end bracket the measured number.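

In this assay, among these compounds, the swap of bromo for methyl on the aromatic ring is the first change in a single place that can be read, and it shows that this position is not silent: a number at least 10.9 percentage points higher from compound 2 to compound 3 (beyond the scatter). Compound 2 gives < 10%, which is a limit of the assay and not a number. The size of the step is therefore known only as a floor, because compound 2 sits at the bottom edge of the read-out: the limit of < 10% in this assay, at which 1 of the 3 values shown sits.

From the compounds shown here alone, whether the rise comes from the arrival of methyl or from the departure of bromo remains open, as a plain hydrogen at this place would be needed to tell them apart. Going by these compounds, how an amine, a carboxylic acid or a longer chain such as propyl would read at this place also remains open.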